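The source may hold more compounds than are shown below. What is called first, only, known or untested is meant among the compounds shown, and "the series" means these compounds.

Of the compounds shown here, three built on one shared core have been tested in a functional assay on U-87MG ATCC cells for antiproliferative activity against U-87 MG (Homo sapiens), read by MTT assay, with a stated time of 48 h, tested at 100 uM; a lower number here means a stronger effect, a higher number a weaker effect of the compound at the concentration tested. Compound 1 `COc1cccc(-c2nc(SCC(=O)c3sc(-c4ccccc4)nc3C)[nH]c(=O)c2C#N)c1` gives 21.8%. Compound 2 `Cc1nc(-c2ccccc2)sc1C(=O)CSc1nc(-c2cccc(Cl)c2)c(C#N)c(=O)[nH]1` gives 10%. Compound 3 `COc1ccc(-c2nc(SCC(=O)c3sc(-c4ccccc4)nc3C)[nH]c(=O)c2C#N)cc1OC` gives 6.48%. Compound 3 thus carries the lowest of the three numbers; its gap to compound 2 lies within the usual scatter of repeated measurements, whereas the step of a number 15.3 percentage points lower from compound 1 to compound 3 (beyond the scatter) lies beyond it.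

Compound 4 `Cc1nc(-c2ccccc2)sc1C(=O)CSc1nc(-c2ccc(Cl)cc2)c(C#N)c(=O)[nH]1` differs from compound 3 in a single place: 4-chlorophenyl in place of 3,4-dimethoxyphenyl on an aromatic carbon. The measured step that bears most directly on this is a number 3.5 percentage points lower from compound 2 to compound 3 (within the scatter), where a chlorophenyl gave way to the dimethoxyphenyl without moving the number beyond the scatter. The step of a number 11.8 percentage points lower from compound 1 to compound 2 (beyond the scatter) was modest and in the lowering direction. Swapping the dimethoxyphenyl back for a chlorophenyl is therefore expected to change the number only slightly, if at all, perhaps a small rise. The expected step is a number 4.5 percentage points higher from compound 3 to compound 4 (within the scatter). Compound 4 is expected to give 11%, within a range from 4% to 22%.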

Compound 4, a percentage reported as activity, at one concentration (the size of the read-out at that concentration, not a potency): 22.5%
Compound 4: middle estimate off by 11.5 percentage points, on the low side, outside the stated range (above it).
By their numbers in this assay, from the lowest: compounds 3 and 2 (each within the scatter of the next); then compounds 1 and 4 (each within the scatter of the next).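

Compound 2 and compound 4 carry the same chlorine and differ only in where it sits on the phenyl ring, yet 4-chlorophenyl in place of 3-chlorophenyl gives a number 12.5 percentage points higher from compound 2 to compound 4 (beyond the scatter) in this assay. The group at this place on the core therefore counts through its substitution pattern, not only through which atom it carries, and a chlorophenyl cannot be treated as one interchangeable group. The other two steps, a number 16 percentage points higher from compound 3 to compound 4 (beyond the scatter) and a number 0.7 percentage points higher from compound 1 to compound 4 (within the scatter), show that 4-chlorophenyl falls level with the 3-methoxyphenyl of compound 1 and does not stay with the 3,4-dimethoxyphenyl of compound 3, and nothing available explains this difference.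

The compounds shown leave open how a phenyl ring with no added group would compare. They also leave open what an amine or a carboxylic acid on that ring would do to the read-out.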